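This account rests on a few compounds, and the source may have more. Where it says the series, first, only, none or still open, it means among the compounds named here.

The three measured compounds, with their exposure in an ADME assay on the whole organism (strain FVB) for pharmacokinetics, with Mus musculus as the target, read by LC-MS, at a dose of 30 mg/kg by the oral route; on this read-out lower numbers stand for lower exposure and higher numbers for higher exposure at the dose given:

Compound 1 `N[C@H]1CC[C@@H](Oc2ccc([C@H]3CC[C@]4(CC3)OOC3(O4)C4CC5CC(C4)CC3C5)cc2)CC1` gives 13400 ng.h/mL.
Compound 2 `c1cc([C@H]2CC[C@]3(CC2)OOC2(O3)C3CC4CC(C3)CC2C4)ccc1OCC1CCNCC1` gives 4040 ng.h/mL.
Compound 3 `c1cc([C@H]2CC[C@]3(CC2)OOC2(O3)C3CC4CC(C3)CC2C4)ccc1OC1CCNCC1` gives 7200 ng.h/mL.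

Compound 2 stands lowest of the three in this assay. Its gap to compound 3 is within the scatter, so the two cannot be ordered, while its gap to compound 1 is beyond the scatter: a 3.3-fold lower number from compound 1 to compound 2 (0.52 log units; beyond the scatter).

Compound 4 `CC1(C)CC(O)(COc2ccc([C@H]3CC[C@]4(CC3)OOC3(O4)C4CC5CC(C4)CC3C5)cc2)CC(C)(C)N1` differs from compound 2 in one place: 4-hydroxy-2,2,6,6-tetramethylpiperidin-4-yl in place of piperidin-4-yl on a saturated chain carbon bound to an oxygen on an aromatic ring. The ring that carries the basic nitrogen is kept, but it now also carries a hydroxy group and four methyl groups.

Going by the values given here, no measured step makes this exact change. Among the compounds with values here, the steps that bear on it all touch the same side chain on the aromatic oxygen: a 1.9-fold lower number from compound 1 to compound 3 (0.27 log units; within the scatter) and a 1.8-fold higher number from compound 2 to compound 3 (0.25 log units; within the scatter), both within the scatter, and a 3.3-fold lower number from compound 1 to compound 2 (0.52 log units; beyond the scatter), which is modest. Changes to this part of the molecule have so far moved exposure in this assay by modest amounts at most, so for compound 4 a step of a 1.2-fold higher number from compound 2 to compound 4 (0.09 log units; within the scatter) is expected, not clearly beyond the scatter in either direction. The estimate for compound 4 in this assay is 5000 ng.h/mL, with a range from 1500 ng.h/mL to 15000 ng.h/mL.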

Compound 4, area under the concentration-time curve: 17300 ng.h/mL
Compound 4: middle estimate off by 3.5-fold (0.54 log units), on the low side; the measured number lies above the stated range.
By their numbers in this assay, from the lowest: compounds 2, 3, 1 and 4 (each within the scatter of the next, the first and the last beyond it).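

In this assay, going by these compounds alone, the ring that carries the nitrogen turns out to accept a hydroxy group and four methyl groups with a clear gain in exposure (a 4.3-fold higher number from compound 2 to compound 4 (0.63 log units; beyond the scatter)), whereas the earlier changes to this side chain gave no step upward from compound 1. The gain also holds against the plain piperidin-4-yl side chain on the oxygen (a 2.4-fold higher number from compound 3 to compound 4 (0.38 log units; beyond the scatter)), while the change from 4-aminocyclohexyl leaves the two compounds impossible to order (a 1.3-fold higher number from compound 1 to compound 4 (0.11 log units; within the scatter)), so the larger (4-hydroxy-2,2,6,6-tetramethylpiperidin-4-yl)methyl side chain matches the exposure of compound 1 and the smaller piperidine side chains do not clearly do so. Nothing available accounts for this rise in exposure.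

The hydroxy group and the four methyl groups enter together, so the compounds shown cannot tell which of them goes with the higher number, or whether both are needed. Also open, going by these compounds, is how the same side chain would read with a methoxy group in place of the hydroxy group, or with the hydroxy group on a piperidine ring that carries no methyl groups.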